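Hydroxy in Place of Hydrogen on the Phenyl Ring

This account rests on a few compounds, and the source may have more. Where it says the series, first, only, none or still open, it means among the compounds named here.

Measured so far in a functional assay on MCF7 cells (Homo sapiens) for cytotoxicity, read by MTT assay, with a stated time of 72 h; a higher number here means a weaker inhibitor, a lower number a stronger inhibitor:
- compound 1 `O=C(CSC(=S)N[C@H]1CCOC1=O)Nc1ccc(Cl)cc1`: 50300 nM
- compound 2 `O=C(CSC(=S)N[C@H]1CCOC1=O)Nc1ccccc1`: limit only, > 128000 nM
- compound 3 `O=C(CSC(=S)N[C@H]1CCOC1=O)Nc1cccc(C(F)(F)F)c1`: 3130 nM

Compound 2 carries the bare phenyl ring, and in this assay it reaches only the limit of the assay, > 128000 nM; no number is known for it. Of the three measured compounds it is the only one that sits at that limit (the limit of > 128000 nM in this assay, at which 1 of the 3 values shown sits), so its true value could lie anywhere above it.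

The step to compound 4 `O=C(CSC(=S)N[C@H]1CCOC1=O)Nc1ccc(O)cc1` is hydroxy in place of hydrogen on an aromatic carbon.

Two measured steps start or end at compound 2. Taking away the chloro gives an at least 2.5-fold higher number from compound 1 to compound 2 (0.40 log units; beyond the scatter), and adding a trifluoromethyl gives an at least 40-fold lower number from compound 2 to compound 3 (1.61 log units; beyond the scatter). Both show that a group on the phenyl ring can move the number, and in these two cases a group gave a lower number than the bare ring. For the measured compounds named here, neither step involves a hydroxy, and no measured compound carries one, so the direction of the new step is open. The expectation is therefore a step of an at least 1.2-fold lower number from compound 2 to compound 4 (0.10 log units; that floor lies within the scatter) in this assay, with a sizeable chance that compound 4 also ends at the limit. Compound 4 is estimated at 100000 nM, with a range from 30000 nM to 300000 nM.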

Compound 4, half-maximal inhibitory concentration: > 128000 nM
Compound 4 was reported as a limit; the forecaster's own chance of this, stated with the estimate: 45%; middle value at least 1.2-fold (0.10 log units) away from the limit.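

For the compounds shown here, compound 4 is the first compound here in which a group on the phenyl ring leaves the read-out at the limit of this assay, so a group at this position does not by itself bring the number down into the measurable range: the chloro does, the hydroxy does not. Putting the hydroxy in place of the chloro at the same place gives an at least 2.5-fold higher number from compound 1 to compound 4 (0.40 log units; beyond the scatter), which separates the two groups at this position, although the size printed is only a floor and the real gap may be larger. The step from the bare phenyl ring cannot be read, since both of its ends are limits and not numbers: the limit of > 128000 nM in this assay, at which 2 of the 4 values shown sit.

On these data alone, how far compound 4 truly lies from compound 2 stays unknown, and with it whether the hydroxy changes anything at all compared with hydrogen. Also open, as far as these compounds go, is whether an amine or a methoxy group at this position would behave like the chloro of compound 1 or like the hydroxy of compound 4.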